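Replacing a Fluorophenyl Arm with a Hydroxy-Methoxyphenyl Arm

A few compounds are considered here, and "the series" means these few. Any claim that something is new, unique, unknown or untested is made for them only; others in the source may bear on it.

Compound 1 `O=C(CSc1nnc(-c2ccncc2)o1)N/N=C/c1ccccc1` gives 22100 nM in a functional assay on BGC-823 cells (Homo sapiens) for cytotoxicity, read by MTT assay, with a stated time of 48 h; on this read-out higher numbers stand for weaker inhibition and lower numbers for stronger inhibition.
Compound 2 `O=C(CSc1nnc(-c2ccncc2)o1)N/N=C/c1cccc(F)c1` gives 27500 nM in this assay.

Among the two measured numbers compound 2 stands highest, with compound 1 as its only neighbour; the step of a 1.2-fold higher number from compound 1 to compound 2 (0.09 log units; within the scatter) shows that swapping a hydrogen for a fluoro on the aromatic carbon left the read-out essentially where it was. Compound 3 `COc1cc(/C=N/NC(=O)CSc2nnc(-c3ccncc3)o2)ccc1O` takes the next step from compound 2: 4-hydroxy-3-methoxyphenyl in place of 3-fluorophenyl on a carbon with a double bond to nitrogen. Within the data shown here, the one measured step, a 1.2-fold higher number from compound 1 to compound 2 (0.09 log units; within the scatter), is the only guide here, and it concerns a different, far smaller change on the same ring; no measured pair shows what a 4-hydroxy-3-methoxyphenyl does in place of a 3-fluorophenyl in this assay. With only a within-scatter step to lean on, the expectation for compound 3 is a step of a 1.4-fold lower number from compound 2 to compound 3 (0.14 log units; within the scatter) that stays close to no change, with a wide range to cover the unknown. The estimate for compound 3 in this assay is therefore 20000 nM, expected to fall between 7000 nM and 60000 nM.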

Compound 3, half-maximal inhibitory concentration: 4320 nM
The estimate for compound 3 lay 4.6-fold (0.67 log units) above the measured number, outside the stated range (below it).
By their numbers in this assay, from the lowest: compound 3; then compounds 1 and 2 (each within the scatter of the next).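

In this assay, the group on the carbon with a double bond to nitrogen proves able to move the read-out: 4-hydroxy-3-methoxyphenyl in place of 3-fluorophenyl gives a 6.4-fold lower number from compound 2 to compound 3 (0.80 log units; beyond the scatter) and, measured against plain phenyl, gives a 5.1-fold lower number from compound 1 to compound 3 (0.71 log units; beyond the scatter) as well. The earlier fluoro swap, a 1.2-fold higher number from compound 1 to compound 2 (0.09 log units; within the scatter), could have suggested that changes on this ring hardly register, but both new steps lie beyond the scatter, although they are modest in size, and they make compound 3 the strongest of the three compounds shown. Nothing given here explains why this change lowers the number, so the result stands as an observation without a known cause.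

The change brings in a hydroxy group and a methoxy group together, so these compounds cannot tell whether one of them alone, as in 4-hydroxyphenyl or 3-methoxyphenyl, would produce the same step or whether both are needed. From the compounds shown here alone, it also remains open how this position would respond to a different kind of group on the ring, such as an amine or a carboxylic acid.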